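The source may report more compounds than this note shows. Statements on the series, on what has been measured and on what is new or still open speak of the compounds shown alone.

Measured compounds:
compound 1, `COc1cc2c(Oc3ccc(NC(=O)c4cc(-c5ccccc5)nc5ccc(F)cc45)cc3F)ccnc2cc1OCCCN1CCCCC1`, 690 nM
compound 2, `COc1cccc(-c2cc(C(=O)Nc3ccc(Oc4ccnc5cc(OCCCN6CCCCC6)c(OC)cc45)c(F)c3)c3cc(F)ccc3n2)c1`, 1610 nM
compound 3, `COc1cc2c(Oc3ccc(NC(=O)c4cc(-c5ccc(C)cc5)nc5ccc(F)cc45)cc3F)ccnc2cc1OCCCN1CCCCC1`, 1050 nM

Of the compounds shown here, three built on one shared core have been tested in a functional assay on U-87MG ATCC cells (Homo sapiens) for cytotoxicity, read by MTT assay, with a stated time of 72 h; on this read-out higher numbers stand for weaker inhibition and lower numbers for stronger inhibition. Compound 3 stands second highest of the three numbers; its nearest neighbour is compound 1, with a 1.5-fold higher number from compound 1 to compound 3 (0.18 log units; within the scatter), and its furthest is compound 2, with a 1.5-fold lower number from compound 2 to compound 3 (0.19 log units; within the scatter), so both gaps fall within the scatter. Going by the values given here, the one step that goes beyond the scatter is a 2.3-fold higher number from compound 1 to compound 2 (0.37 log units; beyond the scatter), a modest one.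

Compound 4, `COc1cc2c(Oc3ccc(NC(=O)c4cc(-c5ccc(C)cc5)nc5ccc(F)cc45)cc3F)ccnc2cc1OCCCN1CCC(C)CC1`, is not yet measured. It differs from compound 3 by methyl in place of hydrogen on a saturated ring carbon. Among the compounds with values here, none of the measured steps touches this place: all three change the group on the aromatic carbon at the other end of the molecule, and even the largest of them is only modest. There is therefore nothing in these data to suggest that a methyl on the saturated ring would move the number far in either direction, and no step beyond the scatter in this assay is expected.

On that basis compound 4 is estimated to give 1050 nM in this assay, within a range from 500 nM to 2200 nM, which corresponds to an expected no change at the digits printed from compound 3 to compound 4 (within the scatter).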

Compound 4, half-maximal inhibitory concentration: 2000 nM
For compound 4 the middle estimate is 1.9-fold (0.28 log units) below the measured one; the measured number falls inside the stated range.
By their numbers in this assay, from the lowest: compounds 1, 3, 2 and 4 (each within the scatter of the next, the first and the last beyond it).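

In this assay, going by these compounds alone, the step from piperidin-1-yl to 4-methylpiperidin-1-yl gives the first reading at the saturated ring, where the earlier steps had only changed the group on the aromatic carbon at the other end of the molecule: a 1.9-fold higher number from compound 3 to compound 4 (0.28 log units; within the scatter) shows that a methyl on this ring carbon, three ring bonds from the ring nitrogen, does not carry the number beyond the scatter. The same exchange of hydrogen for methyl can now be read in two places, since on the aromatic carbon it gave a 1.5-fold higher number from compound 1 to compound 3 (0.18 log units; within the scatter) and neither reading goes beyond the scatter. Nothing given here accounts for the size of the step at the saturated ring.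

Going by these compounds, this single reading on the saturated ring rests on the 4-methylphenyl compound alone, so it remains open whether the methyl would behave alike with the unsubstituted phenyl of compound 1 or the 3-methoxyphenyl of compound 2. On these data alone, it also remains open what a larger group such as ethyl or phenyl, or a hydroxyl group or an amine, would do at the same ring carbon.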